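The compounds below may be only part of what the source reports. "The series", "measured", "known", "first", "only" and "open" are said of these compounds alone.

Compound 3 `S=C(N/N=C/c1ccc2ccccc2n1)Nc1ccc(Cl)cc1` carries a 4-chlorophenyl group on an amide-type nitrogen. In a functional assay on HT-29 cells (Homo sapiens) for antiproliferative activity, read by sulforhodamine B assay, with a stated time of 72 h (on this read-out higher numbers stand for weaker inhibition and lower numbers for stronger inhibition), compound 3 gives 97200 nM, the highest of the two numbers shown. The nearest is compound 2 `CN(C)C(=S)N/N=C/c1ccc2ccccc2n1`, which gives 20 nM in this assay. Compound 1 `Fc1ccccc1NC(=S)N/N=C/c1ccc2ccccc2n1` gives in this assay only a limit, > 100000 nM. Within the data shown here, the single measured step, an at least 1.0-fold lower number from compound 1 to compound 3 (0.01 log units; that floor lies within the scatter), shows that exchanging one aryl group for another left the number at or close to the limit (the limit of > 100000 nM in this assay, at which 1 of the 3 values shown sits). Compound 4 `S=C(N/N=C/c1ccc2ccccc2n1)Nc1ccccc1` differs from compound 3 by hydrogen in place of chloro on an aromatic carbon. This change touches the same aryl group as the earlier step, which was small, so the expected step of a 1.1-fold lower number from compound 3 to compound 4 (0.03 log units; within the scatter) is none beyond the scatter. Compound 4 is therefore expected to give 90000 nM, between 30000 nM and 200000 nM.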

Compound 4, half-maximal inhibitory concentration: 17000 nM
Compound 4: middle estimate off by 5.3-fold (0.72 log units), on the high side, and the stated range ends above it.
By their numbers in this assay, from the lowest: compound 2; then compound 4; then compound 3. At a limit, above all of these: compound 1.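

In this assay the aryl group does respond: hydrogen in place of chloro gives a 5.7-fold lower number from compound 3 to compound 4 (0.76 log units; beyond the scatter), and hydrogen in place of fluoro gives an at least 5.8-fold lower number from compound 1 to compound 4 (0.76 log units; beyond the scatter). The earlier step looked small because compound 1 gives only a limit: the limit of > 100000 nM in this assay, at which 1 of the 4 values shown sits. Even without a halogen on the ring, anilino in place of dimethylamino on the thiocarbonyl carbon still gives an 850-fold higher number from compound 2 to compound 4 (2.93 log units; beyond the scatter). The compounds shown leave open whether a methoxy group or an amine on this ring, or a pyrrolidine in place of the anilino group, would narrow that gap.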